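Pyridin-4-yl gives way to 4-fluorophenyl in compound 4

This account rests on a few compounds, and the source may have more. Where it says the series, first, only, none or still open, it means among the compounds named here.

In a functional assay on FM3A cells (Mus musculus) for antiproliferative activity (on this read-out lower numbers stand for stronger inhibition and higher numbers for weaker inhibition), compound 3 `COc1cc(C(=O)c2sc(-c3ccncc3)cc2N)cc(OC)c1OC` gives 150 nM. Compound 1 `COc1cc(C(=O)c2sc(-c3ccc(Br)cc3)cc2N)cc(OC)c1OC` gives 150 nM, the same number, while compound 2 `COc1cc(C(=O)c2sc(-c3ccc([N+](=O)[O-])cc3)cc2N)cc(OC)c1OC` gives 64 nM, the lowest of the three. Compound 4 `COc1cc(C(=O)c2sc(-c3ccc(F)cc3)cc2N)cc(OC)c1OC`, not yet measured, differs from compound 3 in one place: 4-fluorophenyl in place of pyridin-4-yl on an aromatic carbon. It has 4-fluorophenyl in place of pyridin-4-yl on an aromatic carbon, next to the ring sulfur.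

All three measured steps change this same group. Exchanging 4-bromophenyl for pyridin-4-yl gave no change at the digits printed from compound 1 to compound 3 (within the scatter). Nitro in place of bromo gave a 2.3-fold lower number from compound 1 to compound 2 (0.37 log units; beyond the scatter), and pyridin-4-yl in place of 4-nitrophenyl gave a 2.3-fold higher number from compound 2 to compound 3 (0.37 log units; beyond the scatter); both are modest. Among the measured compounds shown here, no fluorinated compound has been measured, so the closest guide is compound 1 at 150 nM, which also carries a halogen on its phenyl ring. No change beyond the scatter is therefore expected in this assay. The expected step is a 1.3-fold lower number from compound 3 to compound 4 (0.10 log units; within the scatter). For compound 4 the estimate is 120 nM, with an expected range of 50 nM to 300 nM.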

Compound 4, half-maximal inhibitory concentration: 16 nM
Compound 4: the middle estimate sits 7.5-fold (0.88 log units) above what was measured; the whole stated range lies above it.
By their numbers in this assay, from the lowest: compound 4; then compound 2; then compounds 1 and 3 (each within the scatter of the next).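

In this assay, among the compounds shown here, this position turns out to allow a much wider step than the earlier compounds showed, with 4-fluorophenyl in place of pyridin-4-yl giving a 9.4-fold lower number from compound 3 to compound 4 (0.97 log units; beyond the scatter) and not merely matching the other halogen-bearing ring. The halogen itself matters here, since fluoro in place of bromo gives a 9.4-fold lower number from compound 1 to compound 4 (0.97 log units; beyond the scatter) and fluoro in place of nitro gives a 4.0-fold lower number from compound 2 to compound 4 (0.60 log units; beyond the scatter) and so places compound 4 lowest of the four, beyond the scatter from each of the others. No measurement at hand accounts for these steps.

Going by these compounds, it remains open how chloro, methyl or methoxy would read in the place of fluoro, and so whether the low number is particular to fluoro. The same holds for a dimethylamino group or a carboxylic acid on that phenyl ring.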